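Removing the aryl arm from the ether of compound 3

The source may hold more compounds than are shown below. What is called first, only, known or untested is meant among the compounds shown, and "the series" means these compounds.

Measured so far:
compound 1 `CC(C)Cc1cc2oc(=O)n(CCC(=O)O)c2cc1Cl` — 12.6 nM
compound 2 `Cc1ccnc([C@@H](C)Oc2cc3oc(=O)n(CCC(=O)O)c3cc2Cl)c1` — 3.98 nM
compound 3 `C[C@@H](Oc1cc2oc(=O)n(CCC(=O)O)c2cc1Cl)c1ccc(Cl)cn1` — 3.16 nM

In an assay for inhibition of kynurenine 3-monooxygenase (Homo sapiens), read by mass spectrometry, with a stated time of 1 h (a lower number here means a stronger inhibitor, a higher number a weaker inhibitor), compound 3 gives the lowest number of the three. Compound 2 stands nearest, and the step of a 1.3-fold lower number from compound 2 to compound 3 (0.10 log units; within the scatter) is within the scatter, so the two are not told apart. Compound 1 stands furthest, with a higher number beyond the scatter.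

Compound 4 `CCOc1cc2oc(=O)n(CCC(=O)O)c2cc1Cl` differs from compound 3 in one place: hydrogen in place of 5-chloropyridin-2-yl on a saturated chain carbon bound to an oxygen on an aromatic ring and a saturated chain carbon. Going by the values given here, no measured step matches this change. Among the compounds with values here, the only measured step exchanges one six-membered aromatic ring for another on the same saturated chain carbon and is within the scatter; it says nothing about taking the ring away altogether. Within the data shown here, the sole compound without such a ring on a chain, compound 1, gives a higher number than compound 3 in this assay, which points toward a weaker inhibitor when the ring is absent, though the chain of compound 1 is not the same as that of compound 4.

Compound 4 is therefore expected to give a higher number, estimated at 40 nM with a range of 10 nM to 160 nM. The expected step is a 13-fold higher number from compound 3 to compound 4 (1.10 log units; beyond the scatter).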

Compound 4, half-maximal inhibitory concentration: 5.01 nM
Estimate against measurement, compound 4: 8.0-fold (0.90 log units) above, and the stated range ends above it.
By their numbers in this assay, from the lowest: compounds 3, 2 and 4 (each within the scatter of the next); then compound 1.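

Working notes on the ether arm. In this assay, the aryl arm on the saturated chain carbon can be removed with no change that can be told apart: a 1.6-fold higher number from compound 3 to compound 4 (0.20 log units; within the scatter) and a 1.3-fold higher number from compound 2 to compound 4 (0.10 log units; within the scatter) both lie within the scatter, so neither 5-chloropyridin-2-yl nor 4-methylpyridin-2-yl is shown to be required at this place. Losing those 7 heavy atoms of the 5-chloropyridin-2-yl arm therefore leaves the number of compound 4 in the same range as those of compound 2 and compound 3, and the ring's presence no longer accounts for where compound 1 stands. Going by these compounds alone, the one step here beyond the scatter is the exchange of isobutyl for ethoxy on an aromatic carbon, a 2.5-fold lower number from compound 1 to compound 4 (0.40 log units; beyond the scatter), and it is modest.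

The compounds shown leave open whether the ether oxygen or the chain length sets this step, which a methoxy, a propoxy or a plain propyl group on the same aromatic carbon would help to separate. No measured evidence on the cause of these results is available.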